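Tertiary amide at the chain end: expected cytotoxicity

The compounds below may be only part of what the source reports. "The series", "measured", "known", "first", "only" and "open" are said of these compounds alone.

The series shares the core seen in compound 1 `O=C(O)CCC(=O)OCCCCCCSc1ccc([N+](=O)[O-])c2nonc12` and varies only the end of the acid chain. For the measured compounds named here, in an ADME assay on L02 cells (Homo sapiens) for cytotoxicity, read by MTT assay, with a stated time of 72 h (a higher number here means a weaker inhibitor, a lower number a stronger inhibitor), compound 1 gives 1890 nM, the lowest of the three numbers known. Compound 2 `O=C(CCC(=O)OCCCCCCSc1ccc([N+](=O)[O-])c2nonc12)Nc1ccc(F)cc1` gives 6460 nM in this assay, and compound 3 `O=C(CCC(=O)OCCCCCCSc1ccc([N+](=O)[O-])c2nonc12)NCCN1CCCC1` gives 6580 nM. Both amides move the number the same way, a 3.4-fold higher number from compound 1 to compound 2 (0.53 log units; beyond the scatter) and a 3.5-fold higher number from compound 1 to compound 3 (0.54 log units; beyond the scatter), while the two amides sit close to each other, a 1.0-fold higher number from compound 2 to compound 3 (0.01 log units; within the scatter).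

Compound 4 `O=C(CCC(=O)N1CCCCC1)OCCCCCCSc1ccc([N+](=O)[O-])c2nonc12` has not yet been measured. It differs from compound 1 at the same carbonyl carbon: piperidin-1-yl in place of hydroxy on a carbonyl carbon. The carboxy becomes a (piperidin-1-yl)carbonyl, and the one hydrogen-bond donor leaves. The two steps from compound 1 bear directly on this change, as each also replaced the hydroxy on that carbonyl carbon, and both were modest rises beyond the scatter. A rise of similar size is therefore expected for compound 4, with the caveat that no amide lacking a donor has been measured here. The expected step is a 3.2-fold higher number from compound 1 to compound 4 (0.50 log units; beyond the scatter). Compound 4 is estimated at 6000 nM in this assay, within 2500 nM to 14000 nM.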

Compound 4, half-maximal inhibitory concentration: 3970 nM
Estimate against measurement, compound 4: 1.5-fold (0.18 log units) above, and the stated range covers the measured number.
By their numbers in this assay, from the lowest: compound 1; then compounds 4, 2 and 3 (each within the scatter of the next).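

In this assay, piperidin-1-yl in place of hydroxy on a carbonyl carbon gives a 2.1-fold higher number from compound 1 to compound 4 (0.32 log units; beyond the scatter), so a rise beyond the scatter also appears with no hydrogen-bond donor left on the amide. The end group of the amide makes no readable difference among these compounds, with a 1.7-fold lower number from compound 3 to compound 4 (0.22 log units; within the scatter) and a 1.6-fold lower number from compound 2 to compound 4 (0.21 log units; within the scatter). Compounds 2, 3 and 4 therefore all stand apart from compound 1, whether the amide carries 4-fluorophenyl, 2-(pyrrolidin-1-yl)ethyl or the piperidine ring.

From the compounds shown here alone, whether a methyl ester on this carbonyl carbon, or a morpholin-4-yl in place of piperidin-1-yl, would read like compound 1 or like the amides remains open. No evidence at hand accounts for the rise from the carboxy to the amides.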